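Salicylanilide cytotoxicity notes: from compound 2 to compound 4

A few compounds are considered here, and "the series" means these few. Any claim that something is new, unique, unknown or untested is made for them only; others in the source may bear on it.

Measured so far:
compound 1 `O=C(Nc1cc(C(F)(F)F)cc(C(F)(F)F)c1)c1ccc(Cl)cc1O`: 620 nM
compound 2 `N#Cc1ccc(NC(=O)c2cc(Cc3ccccc3)ccc2O)cc1`: 1930 nM
compound 3 `O=C(Nc1cc(C(F)(F)F)cc(C(F)(F)F)c1)c1cc(Br)c(-c2ccccc2)cc1O`: 300 nM

In a functional assay on KG-1 cells (Homo sapiens) for cytotoxicity, read by luminescence and CellTiter-Glo, with a stated time of 3 days (on this read-out higher numbers stand for weaker inhibition and lower numbers for stronger inhibition), compound 2 stands highest of the three, so it is the weakest inhibitor here; compound 1 and compound 3 both lie beyond the scatter below it. Compound 4 `COc1ccc(O)c(C(=O)Nc2ccc(C#N)cc2)c1` is not yet measured. Against compound 2 the change is methoxy in place of benzyl on an aromatic carbon. Going by the values given here, no measured pair isolates this change, so its size cannot be read from the numbers. Compound 3, carrying phenyl and bromo on its core, gives the lowest number, and compound 2 with a benzyl already sits highest; the step to a methoxy is expected to push the number higher, a moderate step beyond the scatter rather than none. Compound 4 is expected to give about 4500 nM, within 1500 nM to 14000 nM, an estimated step of a 2.3-fold higher number from compound 2 to compound 4 (0.37 log units; beyond the scatter).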

Compound 4, half-maximal inhibitory concentration: > 10000 nM
Compound 4 gave a limit, no number; the forecaster's own chance of this, stated with the estimate: 15%; at least 2.2-fold (0.34 log units) between middle value and limit.
By their numbers in this assay, from the lowest: compound 3; then compound 1; then compound 2. At a limit, above all of these: compound 4.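

In this assay, compound 4 gives a limit, not a number: the limit of > 10000 nM in this assay, at which 1 of the 4 values shown sits.

Going by these compounds alone, this pair is the first to isolate the position para to a hydroxy group, and methoxy in place of benzyl there gives an at least 5.1-fold higher number from compound 2 to compound 4 (0.71 log units; beyond the scatter). On these data alone, with the rest of compound 2 unchanged, benzyl goes with the lower number, though the full size of the step stays unknown.

Still open, as far as these compounds go, is whether an amine or a longer alkyl chain at this position would give a number nearer that of benzyl. Also open, from the compounds shown here alone, is whether the step holds with the two trifluoromethyl groups of compound 1 and compound 3.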